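A Chlorine That Switches Off Binding

This account rests on a few compounds, and the source may have more. Where it says the series, first, only, none or still open, it means among the compounds named here.

Of the compounds shown here, three have been measured in an assay on CHO-K1 cells for displacement of a labelled ligand from Neuronal acetylcholine receptor; alpha4/beta2 (Homo sapiens), read by scintillation counting; on this read-out lower numbers stand for stronger inhibition and higher numbers for weaker inhibition. Compound 3 `C[C@@]12C[C@@H]1CC(COc1cccnc1)N2` gives 3.6 nM in this assay. Compound 1 `C[C@@]12C[C@@H]1CC(COc1cccnc1Cl)N2` differs from it by chloro in place of hydrogen on an aromatic carbon. In this assay compound 1 gives > 10000 nM, which is a limit of the assay rather than a number (the limit of > 10000 nM in this assay, at which 1 of the 3 values shown sits). The change produced an at least 2700-fold higher number from compound 3 to compound 1 (3.44 log units; beyond the scatter), a large step.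

Compound 2 `CN1[C@H](COc2cccnc2)C[C@H]2C[C@H]21` has the same atoms as compound 3, joined differently; the difference between the two cores is not broken down here. In this assay compound 2 gives 5.5 nM, which lies within the scatter of compound 3.

Compound 4 `CN1[C@H](COc2cccnc2Cl)C[C@H]2C[C@H]21` is compound 2 carrying the same kind of change, chloro in place of hydrogen on an aromatic carbon, at a place described in the same words: next to the ring nitrogen and ortho to a group of 9 heavy atoms. The step from compound 2 to compound 4 is expected to be a 2700-fold higher number from compound 2 to compound 4 (3.44 log units; beyond the scatter), resting on the measured step of an at least 2700-fold higher number from compound 3 to compound 1 (3.44 log units; beyond the scatter). Compound 4 is therefore estimated at 15000 nM, between 4000 nM and 60000 nM.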

Compound 4, inhibition constant: 28.1 nM
Beside the measured number, compound 4's estimate is 530-fold (2.73 log units) above it; measured number below the stated range.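

In this assay, adding the chloro group gives a 5.1-fold higher number from compound 2 to compound 4 (0.71 log units; beyond the scatter), so a large effect on one core did not carry over at the same size to the other: the same change on two cores in this assay, an at least 2700-fold higher number (3.44 log units; beyond the scatter) from compound 3 to compound 1 and a 5.1-fold higher number (0.71 log units; beyond the scatter) from compound 2 to compound 4, at least 540-fold (2.73 log units) apart, beyond the scatter of two such steps Compound 1 stands at > 10000 nM, which is a limit of the assay and not a number, so the full size of its step remains unknown: the limit of > 10000 nM in this assay, at which 1 of the 4 values shown sits. Both pairs move in the same direction, with a higher number after the change, but two pairs show only that the size of this step depends on the core; they do not explain why, and they give no rule for a third core.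

The compounds shown carry only hydrogen or chloro at this place, so it remains open whether fluoro, bromo or methoxy there would separate the two cores in the same way. Also open, on these data alone, is whether an amino group on another carbon of the aromatic ring would behave differently on the two cores.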